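The source may report more compounds than this note shows. Statements on the series, on what has been measured and on what is new or still open speak of the compounds shown alone.

Measured in a functional assay on HEp-2 cells (Homo sapiens) for cytotoxicity; a higher number here means that more compound is needed for the effect, a lower number that less compound is needed:
- compound 1 `CSc1cc(NC(C)=O)nc2[nH]cnc12` gives > 22 ug/mL, which is a limit of the assay.
- compound 2 `CSc1cc(N)nc2c1ncn2[C@@H]1O[C@H](CO)[C@@H](O)[C@H]1O` gives > 22 ug/mL, likewise a limit of the assay.

Compound 2 thus stands at the limit of > 22 ug/mL in this assay, at which 2 of the 2 values shown sit. Compound 3 `Nc1cc(Cl)c2ncn([C@@H]3O[C@H](CO)[C@@H](O)[C@H]3O)c2n1` differs from compound 2 by chloro in place of methylsulfanyl on an aromatic carbon. Within the data shown here, no step between measured compounds is available, so nothing here indicates how large such a change runs in this assay. No step beyond the scatter is expected; the expected step is a step that the limit leaves unreadable from compound 2 to compound 3. Compound 3 is estimated at 30 ug/mL (range 15 ug/mL to 80 ug/mL) in this assay, most likely again reported only as a limit.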

Compound 3, concentration for half-maximal effect: > 22 ug/mL
Compound 3: a limit, no number (the forecaster's own chance of this, stated with the estimate: 80%); the middle value does not contradict the limit.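

In this assay the results for compound 2 and compound 3 are both limits of the assay, so no step can be read between them. The compounds shown leave open how large a change chloro in place of methylsulfanyl brings in this assay and at which concentration any of them reaches half-maximal effect.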